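The source may report more compounds than this note shows. Statements on the series, on what has been measured and on what is new or still open speak of the compounds shown alone.

Three compounds share a ribose-bearing core and differ only in the aryl group attached to the saturated chain carbon bound to a sulfur. Compound 1 `OC[C@H]1O[C@@H](n2cnc3c(SCc4cccc(Cl)c4)ncnc32)[C@H](O)[C@@H]1O` carries a 3-chlorophenyl there, and in an assay on isolated protein for inhibition of Equilibrative nucleoside transporter 1 (Homo sapiens) (a higher number here means a weaker inhibitor, a lower number a stronger inhibitor), compound 1 gives 18.2 nM. Compound 2 `OC[C@H]1O[C@@H](n2cnc3c(SCc4ccc(Br)cc4)ncnc32)[C@H](O)[C@@H]1O` carries a 4-bromophenyl; in this assay compound 2 gives 11.5 nM. Compound 3 `N#Cc1ccccc1CSc1ncnc2c1ncn2[C@@H]1O[C@H](CO)[C@@H](O)[C@H]1O` carries a 2-cyanophenyl, and in this assay compound 3 gives 38.9 nM, the highest of the three numbers. The steps that lead to it both run upward: a 2.1-fold higher number from compound 1 to compound 3 (0.33 log units; beyond the scatter) and a 3.4-fold higher number from compound 2 to compound 3 (0.53 log units; beyond the scatter), while the step between the two halogenated analogues, a 1.6-fold lower number from compound 1 to compound 2 (0.20 log units; within the scatter), is within the scatter.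

Compound 4 `Cc1cccc(CSc2ncnc3c2ncn3[C@@H]2O[C@H](CO)[C@@H](O)[C@H]2O)c1` has not yet been measured. It differs from compound 3 by 3-methylphenyl in place of 2-cyanophenyl on a saturated chain carbon bound to a sulfur. The two measured steps into compound 3 are the ones that bear on this change, and both are modest increases when the 2-cyanophenyl enters; removing it is therefore expected to bring the number back down by a modest step, roughly to where compound 1 stands with 18.2 nM. For compound 4 the expected step is a 2.0-fold lower number from compound 3 to compound 4 (0.31 log units; beyond the scatter). The estimate for compound 4 in this assay is 19 nM, with a range from 9 nM to 42 nM.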

Compound 4, inhibition constant: 16.2 nM
Estimate against measurement, compound 4: 1.2-fold (0.07 log units) above; measured number inside the range.
By their numbers in this assay, from the lowest: compounds 2, 4 and 1 (each within the scatter of the next); then compound 3.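

In this assay, compound 4 falls in with the two halogenated compounds and not with the 2-cyanophenyl compound: the change away from the nitrile gives a 2.4-fold lower number from compound 3 to compound 4 (0.38 log units; beyond the scatter), while a 1.4-fold higher number from compound 2 to compound 4 (0.15 log units; within the scatter) and a 1.1-fold lower number from compound 1 to compound 4 (0.05 log units; within the scatter) leave it indistinguishable from both. The last of these steps is the closest comparison so far, and it shows that at this position a halogen is not required to stay with compounds 1 and 2, since methyl in place of chloro on an aromatic carbon makes no readable difference. Nothing available explains why the 2-cyanophenyl compound stands apart from the other three.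

The 2-cyanophenyl and 3-methylphenyl groups differ both in the substituent and in where it sits, so the compounds shown cannot tell whether the higher number of compound 3 goes with the nitrile itself or with its place on the ring, a question that 3-cyanophenyl or 2-methylphenyl would address. They also leave open how far this tolerance extends, for instance to a phenyl ring carrying an amine or a carboxylic acid, or to a longer chain between the sulfur and the ring.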